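A few compounds are considered here, and "the series" means these few. Any claim that something is new, unique, unknown or untested is made for them only; others in the source may bear on it.

Measured compounds:
- compound 1, `C=C1C(=O)O[C@@H](C2CCCCC2)[C@H]1c1ccccc1`: 81%
- compound 2, `C=C1C(=O)O[C@@H](c2ccccc2)[C@H]1C`: 14%
- compound 3, `C=C1C(=O)O[C@@H](c2ccc(OC)cc2)[C@H]1C`: 9%

All three were tested in a functional assay on MIA PaCa-2 cells (Homo sapiens) for cytotoxicity, read by MTT assay, with a stated time of 72 h, tested at 10 uM; a higher number here means a weaker effect of the compound at the concentration tested, a lower number a stronger effect. Compound 2 gives 14%, which stands second highest of the three numbers; compound 3 is nearest, and compound 1 is furthest with a much higher number. For the measured compounds named here, the only single-place step among the measured compounds is a number 5 percentage points lower from compound 2 to compound 3 (within the scatter), methoxy in place of hydrogen on an aromatic carbon.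

Compound 4, `C=C1C(=O)O[C@@H](c2ccccc2)[C@H]1c1ccccc1`, has not been measured. It differs from compound 2 in one place: phenyl in place of methyl on a saturated ring carbon. Going by the values given here, no measured step covers this exact change. The step from compound 2 to compound 3 touches a different part of the molecule and was within the scatter, so it gives no guidance here. Compound 1 carries a phenyl on a saturated ring carbon, yet it also differs from compound 2 elsewhere; the value of compound 1, 81%, and that of compound 2 therefore cannot be turned into a clean step. Still, the high number of compound 1 is the only hint at what a phenyl at this position might do, and it points toward a weaker effect.

For compound 4 the estimate is therefore a step of a number 31 percentage points higher from compound 2 to compound 4 (beyond the scatter), giving an expected value of 45% with a range from 12% to 85%.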

Compound 4, a percentage reported as activity, at one concentration (the size of the read-out at that concentration, not a potency): 3%
Compound 4: middle estimate off by 42 percentage points, on the high side; the measured number lies below the stated range.
By their numbers in this assay, from the lowest: compounds 4, 3 and 2 (each within the scatter of the next, the first and the last beyond it); then compound 1.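

In this assay, for the compounds shown here, the saturated ring carbon two ring bonds from the ring oxygen accepts phenyl in place of methyl without any weakening of the effect (a number 11 percentage points lower from compound 2 to compound 4 (beyond the scatter)), something no earlier compound could show. The high number of compound 1 therefore cannot be pinned on the phenyl it carries at this position, since compound 4 has the same phenyl there and differs from compound 1 only on the saturated ring carbon that carries cyclohexyl in compound 1, where phenyl in place of cyclohexyl gives a large change (a number 78 percentage points lower from compound 1 to compound 4 (beyond the scatter)). Among the compounds shown, the weak effect goes with cyclohexyl, which only compound 1 carries, while the three compounds with an aromatic ring on that carbon all have low numbers.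

Nothing available here explains why these changes have the effects they do. Still open, from the compounds shown here alone, is what a longer chain or an amine would do at the carbon that holds methyl or phenyl, and whether a saturated group other than cyclohexyl on the neighbouring position's carbon would behave as cyclohexyl does.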